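A few compounds are considered here, and "the series" means these few. Any claim that something is new, unique, unknown or untested is made for them only; others in the source may bear on it.

In a functional assay on NCI-H1993 cells (Homo sapiens) for inhibition, read by CCK-8 assay, with a stated time of 72 h (on this read-out higher numbers stand for weaker inhibition and lower numbers for stronger inhibition), compound 1 `CC(c1cc2cccnc2cc1F)n1cnc2ncc(-c3cnn(CCO)c3)nc21` gives 175 nM and compound 2 `CC(c1cc2cccnc2cc1F)n1cnc2ncc(-c3ccncc3)nc21` gives 171 nM, so the two stand level within the scatter. For compound 3 `CCC(c1cc2cccnc2cc1F)n1cnc2ncc(-c3ccncc3)nc21`, the entry reads "not determined" (no result reported). Compound 4 `CNC(=O)c1ccc(-c2cnc3ncn(C(C)c4cc5cccnc5cc4F)c3n2)cc1F` has 3-fluoro-4-(methylcarbamoyl)phenyl in place of pyridin-4-yl on an aromatic carbon. Among the compounds with values here, only one measured step bears on this change: a 1.0-fold lower number from compound 1 to compound 2 (0.01 log units; within the scatter), with pyridin-4-yl in place of 1-(2-hydroxyethyl)-1H-pyrazol-4-yl on an aromatic carbon. This single exchange stayed within the scatter, so no large change is expected in this assay, although the group entering compound 4 has not been tested here. The expected step is a 1.6-fold lower number from compound 2 to compound 4 (0.19 log units; within the scatter). For compound 4, the estimated value is 110 nM, with an expected range of 30 nM to 400 nM.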

Compound 4, half-maximal inhibitory concentration: 32.7 nM
Compound 4: the middle estimate sits 3.4-fold (0.53 log units) above what was measured, within the range that was stated.
By their numbers in this assay, from the lowest: compound 4; then compounds 2 and 1 (each within the scatter of the next).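

In this assay, the position that had stayed within the scatter on the earlier exchange now gives a modest step beyond it (a 5.2-fold lower number from compound 2 to compound 4 (0.72 log units; beyond the scatter)) and (a 5.4-fold lower number from compound 1 to compound 4 (0.73 log units; beyond the scatter)). The 3-fluoro-4-(methylcarbamoyl)phenyl group thus stands apart from both pyridin-4-yl and 1-(2-hydroxyethyl)-1H-pyrazol-4-yl, which stood level with each other. Nothing given here accounts for this step. The fluorine and the methylcarbamoyl group enter together, so their shares remain unseparated. A plain phenyl, a 4-carbamoylphenyl or a 4-carboxyphenyl at this place would bear on that.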